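This account rests on a few compounds, and the source may have more. Where it says the series, first, only, none or still open, it means among the compounds named here.

Measured compounds:
- compound 1 `Cc1ccc(-c2nnc(Nc3csc(-c4ccccc4)c3)s2)cc1`: in a functional assay on U-373MG ATCC cells (Homo sapiens) for inhibition, read by colorimetric assay and MTT assay, with a stated time of 72 h (on this read-out lower numbers stand for stronger inhibition and higher numbers for weaker inhibition), compound 1 gives > 100000 nM, which is a limit of the assay and not a number.
- compound 2 `COc1ccc(-c2nnc(Nc3csc(-c4ccccc4)c3)s2)cc1`: in this assay compound 2 gives 92000 nM.
- compound 3 `COc1ccc(-c2nnc(Nc3csc(-c4ccc(C)cc4)c3)s2)cc1`: in this assay compound 3 gives "not determined" (no result reported).

Among these three, compound 2 holds the only measured number; compound 1 sits at the limit (the limit of > 100000 nM in this assay, at which 1 of the 3 values shown sits), and compound 3 has no result. Among the compounds with values here, the one step with two measured compounds runs an at least 1.0-fold lower number from compound 1 to compound 2 (0.03 log units; that floor lies within the scatter), and that step stays within the scatter, so no real movement in the read-out is visible so far.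

Compound 4 `Oc1ccc(-c2nnc(Nc3csc(-c4ccccc4)c3)s2)cc1` differs from compound 2 by hydrogen in place of methyl on an oxygen on an aromatic ring. Within the data shown here, no measured step touches this exact change; the only comparison available, from compound 1 to compound 2, exchanged one small group on that ring position for another without moving the number beyond the scatter. On that basis the expectation is for no step beyond the scatter, that is a 1.0-fold lower number from compound 2 to compound 4 (0.01 log units; within the scatter). Compound 4 is therefore estimated in this assay at 90000 nM, with a range from 30000 nM to 200000 nM.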

Compound 4, half-maximal inhibitory concentration: 58000 nM
For compound 4 the middle estimate is 1.6-fold (0.19 log units) above the measured one; low and high end bracket the measured number.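

In this assay, the change from methoxy to hydroxy gives a 1.6-fold lower number from compound 2 to compound 4 (0.20 log units; within the scatter), so on this aromatic ring position a free hydroxy and a methoxy cannot be told apart by this read-out. Within the data shown here, exchanging methyl for hydroxy at the same place gives an at least 1.7-fold lower number from compound 1 to compound 4 (0.23 log units; that floor lies within the scatter), so three different small groups have now been compared here and no step yet shows a real movement in the number. Compound 1 is a limit of the assay and not a number, so the step from it fixes only a floor: the limit of > 100000 nM in this assay, at which 1 of the 4 values shown sits.

The compounds shown leave open whether an amine, a carboxylic acid or a longer chain such as butoxy in this place would move the number beyond the scatter. They also leave open whether a change elsewhere on the shared core would do so.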